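Compound 1 and its 4-chlorophenyl analogue, compound 4

The source may hold more compounds than are shown below. What is called first, only, known or untested is meant among the compounds shown, and "the series" means these compounds.

Of the compounds shown here, three have so far been measured in a toxicity assay on cells (Macrophage, Mus musculus, strain BALB/c) for cytotoxicity, read by MTT assay; on this read-out lower numbers stand for stronger inhibition and higher numbers for weaker inhibition. Compound 1 `C=CCOc1cc(OC)c(C(=O)/C=C/Cc2ccccc2)c(OCC=C)c1` gives 14800 nM, the lowest of the three numbers shown, yet its nearest neighbour, compound 2 `COc1cc(O)cc(O)c1C(=O)/C=C/c1ccc(Cl)cc1`, gives 19000 nM, and the furthest, compound 3 `COc1cc(O)cc(O)c1C(=O)/C=C/c1ccc(F)cc1`, gives 28800 nM; both gaps are within the scatter, so compound 1 cannot be called the strongest. Going by the values given here, the single measured step between compounds that differ in one place, a 1.5-fold higher number from compound 2 to compound 3 (0.18 log units; within the scatter), also stays within the scatter.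

Compound 4 `C=CCOc1cc(OC)c(C(=O)/C=C/c2ccc(Cl)cc2)c(OCC=C)c1` is yet to be measured. It differs from compound 1 in one place: 4-chlorophenyl in place of benzyl on a double-bonded chain carbon bound to a double-bonded chain carbon. Among the compounds with values here, no measured pair shows exactly this change. Compound 2 carries the same 4-chlorophenyl on another core, and its value and that of compound 1 lie within the scatter of each other; the exchange of chloro for fluoro between compound 2 and compound 3 likewise moved nothing beyond the scatter. With nothing in the data pointing to a shift, compound 4 is expected to show a 1.0-fold higher number from compound 1 to compound 4 (0.01 log units; within the scatter), that is, nothing beyond the scatter. Compound 4 is therefore estimated at 15000 nM, in the range 6000 nM to 40000 nM.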

Compound 4, half-maximal inhibitory concentration: 13000 nM
Beside the measured number, compound 4's estimate is 1.2-fold (0.06 log units) above it; low and high end bracket the measured number.
By their numbers in this assay, from the lowest: compounds 4, 1, 2 and 3 (each within the scatter of the next, the first and the last beyond it).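

In this assay, going by these compounds alone, the exchange of benzyl for 4-chlorophenyl on a double-bonded chain carbon bound to a double-bonded chain carbon gives a 1.1-fold lower number from compound 1 to compound 4 (0.06 log units; within the scatter), the first direct reading of a change at this place on the core of compound 1. The earlier step touched only the halogen on an aromatic carbon of another core, whereas this one replaces the whole group, and the number still stays within the scatter, so in this pair the exchange leaves no measurable mark on the cytotoxicity read-out. No evidence on any measured property of these compounds bears on this result.

The step joins two differences in one, the shift from benzyl to a ring without its chain carbon and the arrival of chloro, and the compounds shown, which include no plain phenyl at this place, cannot separate them. Going by these compounds, whether this place tolerates any group at all also stays open, since an amine, a carboxylic acid or a longer chain here could still move the number beyond the scatter.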